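A few compounds are considered here, and "the series" means these few. Any claim that something is new, unique, unknown or untested is made for them only; others in the source may bear on it.

Compound 3 `CNCC(=O)NC[C@@H]1CCCc2cc(S(=O)(=O)c3cccc(F)c3)ccc21` sits second highest of the three numbers in an assay on isolated protein for displacement of a labelled ligand from 5-hydroxytryptamine receptor 6 (Homo sapiens) (a higher number here means a weaker inhibitor, a lower number a stronger inhibitor), where compound 3 gives 0.159 nM. Its nearest neighbour is compound 1 `NC[C@@H]1CCCc2cc(S(=O)(=O)c3cccc(F)c3)ccc21`, which in this assay gives 0.0794 nM; the gap a 2.0-fold higher number from compound 1 to compound 3 (0.30 log units; within the scatter) lies within the scatter. Its furthest neighbour is compound 2 `CN(C)S(=O)(=O)NC[C@@H]1CCCc2cc(S(=O)(=O)c3cccc(F)c3)ccc21`, which gives 2 nM; the step of a 13-fold lower number from compound 2 to compound 3 (1.10 log units; beyond the scatter) is a large one. Compound 4 `CNC(=O)NC[C@@H]1CCCc2cc(S(=O)(=O)c3cccc(F)c3)ccc21` differs from compound 3 by one change: methylamino in place of (methylamino)methyl on a carbonyl carbon. For the measured compounds named here, two measured steps bear on this. The step of a 25-fold higher number from compound 1 to compound 2 (1.40 log units; beyond the scatter) shows that a cap on the amine nitrogen can cost a great deal, while a 2.0-fold higher number from compound 1 to compound 3 (0.30 log units; within the scatter) shows that the cap carried by compound 3 costs almost nothing. Compound 4 keeps a cap but loses the methylamino group at the end of the chain, so a moderate rise in the number is expected, short of what compound 2 shows. The estimate for compound 4 is 0.6 nM, within 0.15 nM to 2.5 nM, an expected step of a 3.8-fold higher number from compound 3 to compound 4 (0.58 log units; beyond the scatter).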

Compound 4, inhibition constant: 0.398 nM
For compound 4 the middle estimate is 1.5-fold (0.18 log units) above the measured one; measured number inside the range.
By their numbers in this assay, from the lowest: compounds 1 and 3 (each within the scatter of the next); then compound 4; then compound 2.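

Replacing (methylamino)methyl with methylamino on the carbonyl carbon moves the number beyond the scatter, though only modestly (a 2.5-fold higher number from compound 3 to compound 4 (0.40 log units; beyond the scatter)). In this assay, then, this position does respond to the change, even with just one heavy atom fewer and one hydrogen-bond acceptor fewer. The methylcarbamoyl cap also sits apart from both the uncapped amine (a 5.0-fold higher number from compound 1 to compound 4 (0.70 log units; beyond the scatter)) and the dimethylsulfamoyl cap (a 5.0-fold lower number from compound 2 to compound 4 (0.70 log units; beyond the scatter)), so among these compounds a cap on the amine nitrogen need not either cost almost nothing or cost a great deal.

The compounds shown leave open how an ethylamino or dimethylamino group on the carbonyl carbon, or a longer chain ending in an amine, would behave here. Nothing available explains why these steps take the sizes they do.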